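The compounds below may be only part of what the source reports. "The series", "measured", "known", "first", "only" and "open" are said of these compounds alone.

Measured in a functional assay on Hs 683 cells (Homo sapiens) for inhibition, read by MTT assay, with a stated time of 72 h; on this read-out lower numbers stand for stronger inhibition of growth and higher numbers for weaker inhibition of growth:
- compound 1 `CC(C)(C)OC(=O)/C=C/C1=CC[C@H]2C(C)(C)CCC[C@]2(C)[C@H]1C=O`: 29000 nM
- compound 2 `CC1(C)CCC[C@]2(C)[C@@H](C=O)C(/C=C/C(=O)OCc3ccccc3)=CC[C@@H]12`: 31000 nM
- compound 3 `COC(=O)/C=C/C=C/C1=CC[C@H]2C(C)(C)CCC[C@]2(C)[C@H]1C=O`: 12000 nM

Of these three, compound 3 has the lowest number, 12000 nM. Compound 4 `C#CCCCOC(=O)/C=C/C1=CC[C@H]2C(C)(C)CCC[C@]2(C)[C@H]1C=O` differs from it by carrying ((pent-4-yn-1-yl)oxy)carbonyl in place of 2-(methoxycarbonyl)ethenyl on a double-bonded chain carbon bound to a double-bonded chain carbon.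

For the measured compounds named here, two measured steps bear on this change. Replacing tert-butoxycarbonyl with 2-(methoxycarbonyl)ethenyl at that same place gave a 2.4-fold lower number from compound 1 to compound 3 (0.38 log units; beyond the scatter), a modest step, and the present change runs largely the opposite way. Exchanging the group on the ester oxygen, benzyl for tert-butyl, gave a 1.1-fold higher number from compound 1 to compound 2 (0.03 log units; within the scatter). On these two steps alone, compound 4 is expected to read close to compound 1 and compound 2 in this assay, although no pent-4-yn-1-yl ester has been measured. The expected result is a 2.2-fold higher number from compound 3 to compound 4 (0.34 log units; beyond the scatter). For compound 4 the estimated value is 26000 nM, with an expected range from 13000 nM to 50000 nM.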

Compound 4, concentration for 50% growth inhibition: 33000 nM
Compound 4: the middle estimate sits 1.3-fold (0.10 log units) below what was measured; the range from low to high includes it.
By their numbers in this assay, from the lowest: compound 3; then compounds 1, 2 and 4 (each within the scatter of the next).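

In this assay, a straight chain ending in a triple bond on the ester oxygen reads like the two branched or aromatic groups there: a 1.1-fold higher number from compound 1 to compound 4 (0.06 log units; within the scatter) and a 1.1-fold higher number from compound 2 to compound 4 (0.03 log units; within the scatter), so tert-butyl, benzyl and pent-4-yn-1-yl cannot be told apart in this assay. The exchange at the place itself gives a 2.8-fold higher number from compound 3 to compound 4 (0.44 log units; beyond the scatter), a modest step, and with this third ester compound 3 stands alone among the four as the only one beyond the scatter of the others. Nothing available explains why these ester groups read alike or why compound 3 separates from them.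

The compounds shown leave open whether the separation of compound 3 follows from its longer unsaturated chain or from its methyl ester. On these data alone, how a carboxylic acid or an amide would read at this place also remains open.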